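Changing the Benzyl Ring: From Compound 2 to Compound 4

The source may report more compounds than this note shows. Statements on the series, on what has been measured and on what is new or still open speak of the compounds shown alone.

Three compounds have been measured in a functional assay on EC9706 cells (Homo sapiens) for cytotoxicity, read by MTT assay, with a stated time of 72 h; on this read-out higher numbers stand for weaker inhibition and lower numbers for stronger inhibition:
- compound 1 `CC(C)NC(=O)N1CCN(C(=S)SCc2cn(Cc3ccccc3F)nn2)CC1` gives 20800 nM
- compound 2 `CCN(C)C(=O)N1CCN(C(=S)SCc2cn(Cc3ccccc3F)nn2)CC1` gives 15600 nM
- compound 3 `O=C(NC1CCCCC1)N1CCN(C(=S)SCc2cn(Cc3ccccc3F)nn2)CC1` gives 84900 nM

Compound 2 has the lowest of the three numbers, but its gap to compound 1, a 1.3-fold lower number from compound 1 to compound 2 (0.12 log units; within the scatter), is within the scatter, so the two cannot be told apart. Compound 3 stands clearly apart: a 4.1-fold higher number from compound 1 to compound 3 (0.61 log units; beyond the scatter) and a 5.4-fold higher number from compound 2 to compound 3 (0.74 log units; beyond the scatter), both beyond the scatter.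

Compound 4 `CCN(C)C(=O)N1CCN(C(=S)SCc2cn(Cc3ccc(C)cc3)nn2)CC1` differs from compound 2 in one place: 4-methylphenyl in place of 2-fluorophenyl on a saturated chain carbon bound to an aromatic nitrogen. Within the data shown here, every measured step so far concerns the group attached to the carbonyl carbon at the other end of the shared core; none touches the ring on the saturated chain carbon bound to the aromatic nitrogen. Among the measured compounds shown here, no measured step therefore bears on this change, and there is no basis for expecting a move in either direction. The plain expectation is no step beyond the scatter in this assay, held with little confidence and so with a wide range.

Compound 4 is expected to give about 15600 nM, within a range from 4000 nM to 60000 nM. The expected step from compound 2 to compound 4 is no change at the digits printed from compound 2 to compound 4 (within the scatter).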

Compound 4, half-maximal inhibitory concentration: 70600 nM
Compound 4: middle estimate off by 4.5-fold (0.66 log units), on the low side; the whole stated range lies below it.
By their numbers in this assay, from the lowest: compounds 2 and 1 (each within the scatter of the next); then compounds 4 and 3 (each within the scatter of the next).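

Swapping the ring on the saturated chain carbon bound to an aromatic nitrogen moves the result in this assay: the change from 2-fluorophenyl to 4-methylphenyl gives a 4.5-fold higher number from compound 2 to compound 4 (0.66 log units; beyond the scatter) as a modest step that goes toward weaker inhibition. Among these compounds, until now, every measured step concerned the group on the carbonyl carbon, so this is the first sign that the number also responds to a change at this other end of the shared core. The change removes a fluorine, adds a methyl and alters where the ring carries its substituent, all in one step, and nothing available here explains why the number moves.

Plain phenyl, 4-fluorophenyl or 2-methylphenyl at this place, with the ethyl(methyl)amino group kept on the carbonyl carbon, would help separate the identity of the substituent from its location on the ring. On these data alone, it also remains open whether 2-fluorobenzyl to 4-methylbenzyl would give a similar step in compounds with isopropylamino or cyclohexylamino on the carbonyl carbon.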